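Compound 2 to compound 4: one methyl group removed

A few compounds are considered here, and "the series" means these few. Any claim that something is new, unique, unknown or untested is made for them only; others in the source may bear on it.

Compound 1 (`COc1ccc(/C(=N/O)c2cccc3ccccc23)c(OC)c1OC`) gives 2500 nM
Compound 2 (`COc1ccc(C(O)(Cc2ccc(C)cc2)c2cccc3ccccc23)c(OC)c1OC`) gives > 20000 nM (a limit)
Compound 3 (`COc1cc(COC(c2ccc(OC)c(OC)c2OC)c2cccc3ccccc23)cc(OC)c1`) gives > 20000 nM (a limit)

In a functional assay on MDA-MB-231 cells (Homo sapiens) for inhibition, read by sulforhodamine B assay, with a stated time of 48 h (a lower number here means a stronger inhibitor, a higher number a weaker inhibitor), compound 2 stands at > 20000 nM, which is a limit of the assay and not a number. The shared boundary here is the limit of > 20000 nM in this assay, at which 2 of the 3 values shown sit, so only compound 1 has an exact reading. Compound 4 (`COc1ccc(C(O)(Cc2ccccc2)c2cccc3ccccc23)c(OC)c1OC`) differs from compound 2 by one small edit: hydrogen in place of methyl on an aromatic carbon, para to a large group. Among the measured compounds shown here, no measured pair shows this change, so no shift beyond the usual scatter is expected. The expected a number no higher from compound 2 to compound 4 (the limit leaves the size open) therefore has no clear direction. Compound 4 is estimated at 20000 nM, with an expected range from 7000 nM to 50000 nM.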

Compound 4, half-maximal inhibitory concentration: 4780 nM
Compound 4: middle estimate off by 4.2-fold (0.62 log units), on the high side; measured number below the stated range.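

In this assay, replacing the methyl of the 4-methylbenzyl group with hydrogen to give a benzyl group produces a clear change: an at least 4.1-fold lower number from compound 2 to compound 4 (0.62 log units; beyond the scatter). Among the compounds shown here, the earlier compounds included no pair differing in one place, so this is the first evidence that this carbon, para to a large group, affects the reading. The full size of the step remains unknown, since it starts from a limit of the assay and not a number: the limit of > 20000 nM in this assay, at which 2 of the 4 values shown sit.

Going by these compounds, whether a fluorine atom, a hydroxyl group or an amine on that same carbon would read more like the hydrogen or the methyl remains open.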